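Aryl piperazine swap at the weak end of the series

A few compounds are considered here, and "the series" means these few. Any claim that something is new, unique, unknown or untested is made for them only; others in the source may bear on it.

Compound 2 `COc1cccc(N2CCN(Cn3nc(-c4ccc5c(c4)OCCO5)oc3=S)CC2)c1` gives only a limit in a functional assay on SW 1116 cells (Homo sapiens) for antiproliferative activity, read by MTT assay, with a stated time of 48 h; a higher number here means a weaker inhibitor, a lower number a stronger inhibitor: > 50000 nM, which is the assay limit. Going by the values given here, its partner compound 1 `S=c1oc(-c2ccc3c(c2)OCCO3)nn1CN1CCN(c2cccc(Cl)c2Cl)CC1` gives 37100 nM in this assay, so both sit at the weak end of what the assay resolves; the only measured step, an at least 1.3-fold higher number from compound 1 to compound 2 (0.12 log units; that floor lies within the scatter), runs from 2,3-dichlorophenyl to 3-methoxyphenyl. Compound 3 `S=c1oc(-c2ccc3c(c2)OCCO3)nn1CN1CCN(c2ccccc2Cl)CC1` is not yet measured. It differs from compound 2 by 2-chlorophenyl in place of 3-methoxyphenyl on an amine nitrogen in a ring. Among the compounds with values here, the one measured step is the only guide, and it lies at the floor of the scatter, with compound 2 sitting at the limit of > 50000 nM in this assay, at which 1 of the 2 values shown sits, so the change back toward a chlorinated phenyl is expected to move the number little, if at all, beyond the scatter in this assay. Compound 3 is therefore expected near 42000 nM, in the range 15000 nM to 120000 nM. This estimate means an expected step of an at least 1.1-fold lower number from compound 2 to compound 3 (0.07 log units; that floor lies within the scatter).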

Compound 3, half-maximal inhibitory concentration: > 50000 nM
Compound 3 ended at the assay's limit; the forecaster's own chance of this, stated with the estimate: 45%; middle value at least 1.1-fold (0.07 log units) from the limit.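

Hydrogen in place of chloro on an aromatic carbon gives an at least 1.3-fold higher number from compound 1 to compound 3 (0.12 log units; that floor lies within the scatter) in this assay, so the one readable step from the 2,3-dichlorophenyl of compound 1 stays small. The step between compound 2 and compound 3 cannot be read, as both values are limits, and 2-chlorophenyl and 3-methoxyphenyl on the amine nitrogen in a ring therefore cannot be ordered. Of the three aryl groups at this position, only 2,3-dichlorophenyl gives a number rather than a limit: the limit of > 50000 nM in this assay, at which 2 of the 3 values shown sit.

On these data alone, how far compound 2 and compound 3 lie beyond the limit remains open, and with it whether either truly differs from compound 1. Also open, as far as these compounds go, is whether a 4-fluorophenyl or a benzyl group on this nitrogen would give a readable number in this assay.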